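A few compounds are considered here, and "the series" means these few. Any claim that something is new, unique, unknown or untested is made for them only; others in the source may bear on it.

Three compounds, compound 1 `CCOC(=O)Cn1ncc2c(C)ncn2c1=O`, compound 2 `CCCc1nc(C)c2cnn(CC(=O)OCC)c(=O)n12` and compound 3 `CCCc1nc(C)c2c(C)nn(CC(=O)OCC)c(=O)n12`, were tested in a functional assay for inhibition, with Homo sapiens as the target; a lower number here means a stronger inhibitor, a higher number a weaker inhibitor. For compound 1 the result is only a limit of the assay, > 48000 nM. Compound 2 likewise gives only a limit, > 48000 nM. Compound 3 also gives only a limit, > 48000 nM. Because (the limit of > 48000 nM in this assay, at which 3 of the 3 values shown sit), the steps a step that the two limits leave unreadable from compound 1 to compound 2 and a step that the two limits leave unreadable from compound 2 to compound 3 cannot be read in size or direction. Compound 4 `CCCc1nc(C)c2cnn(CC3CC3)c(=O)n12` differs from compound 2 by cyclopropyl in place of ethoxycarbonyl on a saturated chain carbon bound to an aromatic nitrogen. Among the measured compounds shown here, no measured step covers this change, so there is nothing from which a direction could be read. Compound 4 is therefore expected to stay near the limit, a step that the limit leaves unreadable from compound 2 to compound 4. The estimate for compound 4 is 60000 nM, ranging from 15000 nM to 250000 nM.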

Compound 4, half-maximal inhibitory concentration: > 48000 nM
Compound 4 gave a limit, no number; the forecaster's own chance of this, stated with the estimate: 80%; the middle value lies beyond the limit too.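

Compound 4, like compound 2, gives only a limit, so swapping ethoxycarbonyl for cyclopropyl yields no readable step: the limit of > 48000 nM in this assay, at which 4 of the 4 values shown sit. The compounds shown leave open which change to the shared core, if any, would give a true number in this assay.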